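The source may report more compounds than this note shows. Statements on the series, on what has been measured and on what is new or still open speak of the compounds shown alone.

Compound 1 `COc1cc2nc(N3CCN(S(=O)(=O)c4ccc(I)cc4)CC3)nc(N)c2cc1OC`: 15000 nM
Compound 2 `COc1cc2nc(N3CCN(S(=O)(=O)c4ccc(C)cc4)CC3)nc(N)c2cc1OC`: 30000 nM
Compound 3 `COc1cc2nc(N3CCN(S(=O)(=O)c4cccc5ccccc45)CC3)nc(N)c2cc1OC`: 14000 nM

These three compounds were measured in a functional assay on PC-3 cells (Homo sapiens) for inhibition; a lower number here means a stronger inhibitor, a higher number a weaker inhibitor. Compound 3 gives the lowest of the three numbers in this assay, but its standing is uneven: the step from compound 1 a 1.1-fold lower number from compound 1 to compound 3 (0.03 log units; within the scatter) stays within the scatter, whereas the step from compound 2 a 2.1-fold lower number from compound 2 to compound 3 (0.33 log units; beyond the scatter) is a modest one beyond it. The step between compound 1 and compound 2 a 2.0-fold higher number from compound 1 to compound 2 (0.30 log units; within the scatter) is itself within the scatter.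

Compound 4 `COc1cc2nc(N3CCN(S(=O)(=O)c4ccc5ccccc5c4)CC3)nc(N)c2cc1OC` has not yet been measured in this assay. It differs from compound 3 in one place: naphthalen-2-yl in place of naphthalen-1-yl on a sulfonyl sulfur. The two compounds have the same atoms, joined differently.

Of the measured steps, only those that bring in naphthalen-1-yl, from compound 1 and from compound 2, touch this part of the structure, and both were small. For the measured compounds named here, none of them concerns a shift between the two naphthyl attachments, so there is no direct precedent for the change to compound 4. Given how close all three measured numbers lie, the step from compound 3 to compound 4 is expected to be a 1.1-fold higher number from compound 3 to compound 4 (0.03 log units; within the scatter), with no clear direction beyond the scatter. Compound 4 is therefore estimated at 15000 nM in this assay, within a range from 6000 nM to 40000 nM.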

Compound 4, half-maximal inhibitory concentration: 15000 nM
For compound 4 middle estimate and measured number coincide at the digits printed, and the stated range covers the measured number.
By their numbers in this assay, from the lowest: compounds 3, 1, 4 and 2 (each within the scatter of the next, the first and the last beyond it).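

Changing naphthalen-1-yl to naphthalen-2-yl on the sulfonyl sulfur gives a 1.1-fold higher number from compound 3 to compound 4 (0.03 log units; within the scatter) in this assay, so this change of attachment, which keeps the same atoms, does not separate the two compounds. Compound 4 also cannot be told apart from the other two aryl sulfonyl compounds, with no change at the digits printed from compound 1 to compound 4 (within the scatter) and a 2.0-fold lower number from compound 2 to compound 4 (0.30 log units; within the scatter) both lying within the scatter. For the compounds shown here, the one step beyond the scatter, a 2.1-fold lower number from compound 2 to compound 3 (0.33 log units; beyond the scatter), therefore has no counterpart with naphthalen-2-yl and does not establish a shared effect of the naphthyl groups, although the margin between these two steps is thin. Nothing shown explains why these aryl groups give such similar numbers.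

On these data alone, all four compounds carry an aryl group made of carbon, apart from the iodo substituent, so it remains open whether a pyridine ring or a phenyl ring bearing an amine or a carboxylic acid would move the number beyond the scatter. The compounds shown also leave open how far a group other than the sulfonyl, such as a carbonyl, would change the result on the same core.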